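This account rests on a few compounds, and the source may have more. Where it says the series, first, only, none or still open, it means among the compounds named here.

Measured so far in a functional assay on A-375 cells (Homo sapiens) for antiproliferative activity, read by MTT assay, with a stated time of 24 h; a higher number here means a weaker inhibitor, a lower number a stronger inhibitor:
compound 1, `COc1cc(OC)c(-c2coc3cc(OCc4ccccc4F)ccc3c2=O)cc1OC`, 2100 nM;
compound 2, `COc1cc(OC)c(-c2coc3cc(OCc4ccc(Br)cc4)ccc3c2=O)cc1OC`, 1000 nM;
compound 3, `COc1cc(OC)c(-c2coc3cc(OCc4ccccc4C)ccc3c2=O)cc1OC`, 1360 nM.

For the measured compounds named here, compound 3 stands inside the usual scatter of both other compounds: the step of a 1.5-fold lower number from compound 1 to compound 3 (0.19 log units; within the scatter) and the step of a 1.4-fold higher number from compound 2 to compound 3 (0.13 log units; within the scatter) each fall within it, and only the step of a 2.1-fold lower number from compound 1 to compound 2 (0.32 log units; beyond the scatter) reaches beyond. Compound 4, `COc1cc(OC)c(-c2coc3cc(OCc4cccc(Br)c4)ccc3c2=O)cc1OC`, differs from compound 3 in one place: 3-bromophenyl in place of 2-methylphenyl on a saturated chain carbon bound to an oxygen on an aromatic ring. Going by the values given here, the steps that bear on this are the exchanges of one substituted phenyl for another on that same saturated chain carbon, the modest step of a 2.1-fold lower number from compound 1 to compound 2 (0.32 log units; beyond the scatter) and the step of a 1.4-fold higher number from compound 2 to compound 3 (0.13 log units; within the scatter). Compound 2 already carries a bromine on its phenyl, and its number sits within the scatter of compound 3. Compound 4 is therefore expected to show no step beyond the scatter, a 1.2-fold lower number from compound 3 to compound 4 (0.09 log units; within the scatter), with an estimated 1100 nM and a range from 500 nM to 2500 nM.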

Compound 4, half-maximal inhibitory concentration: 1120 nM
Beside the measured number, compound 4's estimate is 1.0-fold (0.01 log units) below it; measured number inside the range.
By their numbers in this assay, from the lowest: compounds 2, 4, 3 and 1 (each within the scatter of the next, the first and the last beyond it).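

In this assay the 3-bromophenyl of compound 4 cannot be told from the 4-bromophenyl of compound 2 (a 1.1-fold higher number from compound 2 to compound 4 (0.05 log units; within the scatter)), so the two bromine placements shown give no separable numbers. It also cannot be told from 2-methylphenyl (a 1.2-fold lower number from compound 3 to compound 4 (0.08 log units; within the scatter)) or from 2-fluorophenyl (a 1.9-fold lower number from compound 1 to compound 4 (0.27 log units; within the scatter)). Compound 4 therefore has no step beyond the scatter to any compound shown, whereas compound 2 has one to compound 1. No measurement here accounts for these steps. Going by these compounds, whether an amine, a carboxylic acid or a pyridine ring on this saturated chain carbon would give a step beyond the scatter remains open.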